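Valine acid in place of asparagine on the chloropurine core

The compounds below may be only part of what the source reports. "The series", "measured", "known", "first", "only" and "open" are said of these compounds alone.

Three compounds share a core and were measured in a functional assay on the whole organism (Tail, strain ICR) with Mus musculus as the target, in the tail flick test, with a stated time of 150 min, at a dose of 25 umol/kg by the oral route; a lower number here means a weaker effect, a higher number a stronger effect of the compound at the dose given. Compound 1 `O=C(O)[C@@H]1CCCN1C(=O)CN(c1nc(Cl)nc2[nH]cnc12)C1CC1` gives 7.29%. Compound 2 `CC(C)[C@H](NC(=O)CN(c1nc(Cl)nc2[nH]cnc12)C1CC1)C(=O)OCc1ccccc1` gives 17.9%. Compound 3 `NC(=O)C[C@H](NC(=O)CN(c1nc(Cl)nc2[nH]cnc12)C1CC1)C(=O)O` gives 7.51%, the second highest of the three numbers; its nearest neighbour is compound 1, a value within the usual scatter, and the furthest is compound 2, a value beyond it.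

Compound 4 `CC(C)[C@H](NC(=O)CN(c1nc(Cl)nc2[nH]cnc12)C1CC1)C(=O)O` has not yet been measured in this assay. The change from compound 3 reads (isopropyl in place of carbamoylmethyl on a saturated chain carbon bound to an amide-type nitrogen and a carbonyl carbon). Going by the values given here, no pair of measured compounds differs in just this way, so no measured step guides the expectation. The two compounds that carry a free carboxylic acid, compound 1 and compound 3, sit close together, while the higher value belongs to compound 2 with its benzyl ester.

For compound 4 the step is expected to be small, a number 2.5 percentage points higher from compound 3 to compound 4 (within the scatter), with a slight upward lean that may not exceed the scatter. The estimated value for compound 4 is 10%, within a range from 3% to 20%.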

Compound 4, a percentage reported as activity, at one dose (the size of the read-out at that dose, not a potency): 7.86%
Estimate against measurement, compound 4: 2.1 percentage points above, and the stated range covers the measured number.
By their numbers in this assay, from the lowest: compounds 1, 3, 4 and 2 (each within the scatter of the next, the first and the last beyond it).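

In this assay, going by these compounds alone, the exchange of carbamoylmethyl for isopropyl on a saturated chain carbon bound to an amide-type nitrogen and a carbonyl carbon gives a number 0.4 percentage points higher from compound 3 to compound 4 (within the scatter) and thus gives the first measured step at this position, one that does not separate the two side chains. The other two steps also stay inside the scatter: hydrogen in place of benzyl on an oxygen next to a carbonyl group gives a number 10 percentage points lower from compound 2 to compound 4 (within the scatter) and (1-carboxy-2-methylpropyl)amino in place of 2-carboxypyrrolidin-1-yl on a carbonyl carbon gives a number 0.6 percentage points higher from compound 1 to compound 4 (within the scatter). No supporting measurement offers an explanation for these results.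

The compounds shown leave open what a methyl ester would give in place of the benzyl ester on the shared core. They also leave open whether a longer chain or an amine in place of isopropyl at this position would yield a step beyond the scatter.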